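The source may hold more compounds than are shown below. What is called first, only, known or untested is meant among the compounds shown, and "the series" means these compounds.

Measured so far in an ADME assay on cells (Hepatocyte, Rattus norvegicus) for metabolic stability, using equilibrium dialysis; on this read-out lower numbers stand for slow clearance and higher numbers for fast clearance:
compound 1, `CC(=O)N[C@@H]1CCC[C@H](C(=O)Nc2cc(-c3cnn(C)c3C)c(Cl)cn2)C1`: compound 1 gives 10 uL/min
compound 2, `CC(=O)N[C@@H]1CCC[C@H](C(=O)Nc2cc(-c3cnn4c3CN(C)CC4)c(Cl)cn2)C1`: compound 2 gives 7.7 uL/min

Compound 2 holds the lowest of the two numbers in this assay; its nearest neighbour is compound 1, and the step of a 1.3-fold lower number from compound 1 to compound 2 (0.11 log units; within the scatter) lies within the scatter, so the two compounds cannot be ordered against each other.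

Compound 3, `CC(=O)N[C@@H]1CCC[C@H](C(=O)Nc2cc(-c3cnn4c3NCCC4)c(Cl)cn2)C1`, has not yet been measured. Set against compound 2 the change is a group of 9 heavy atoms (6 carbon, 3 nitrogen; one five-membered aromatic ring with 2 hetero atoms, one six-membered non-aromatic ring with 2 hetero atoms) in place of a group of 10 heavy atoms (7 carbon, 3 nitrogen; one five-membered aromatic ring with 2 hetero atoms, one six-membered non-aromatic ring with 2 hetero atoms), on an aromatic carbon. For the measured compounds named here, only one measured step concerns the same place on the shared core, a 1.3-fold lower number from compound 1 to compound 2 (0.11 log units; within the scatter), and it stayed within the scatter. Going by the values given here, that step, however, exchanged groups without adding a hydrogen-bond donor, so the present change is not covered directly; no other step is available. Among the compounds with values here, with the single relevant step a 1.3-fold lower number from compound 1 to compound 2 (0.11 log units; within the scatter) within the scatter, the step expected from compound 2 to compound 3 in this assay, a 1.0-fold higher number from compound 2 to compound 3 (0.02 log units; within the scatter), is none beyond the scatter. Compound 3 is therefore estimated at 8 uL/min, with a range from 4 uL/min to 16 uL/min, the width of the range reflecting the lack of a directly comparable step.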

Compound 3, intrinsic clearance in a liver preparation (reported as CLH), per the amount of preparation that the assay uses in the Hepatocyte assay: 10 uL/min
For compound 3 the middle estimate is 1.3-fold (0.10 log units) below the measured one, and the stated range covers the measured number.
By their numbers in the Hepatocyte assay, from the lowest: compounds 2, 1 and 3 (each within the scatter of the next).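

In the Hepatocyte assay, the group of compound 3, the first in the series with 1 hydrogen-bond donor at this aromatic carbon ortho to a chloro group, gives a 1.3-fold higher number from compound 2 to compound 3 (0.11 log units; within the scatter) and no change at the digits printed from compound 1 to compound 3 (within the scatter), so all three groups at this position now lie within the scatter of one another and a donor in the entering group brings no readable shift in clearance. In a physicochemical assay for solubility, in phosphate buffer, at pH 7.4 (a higher number here means a more soluble compound, a lower number a less soluble compound), compound 2 gives 870000 nM and compound 3 gives 860000 nM, two values within the scatter of each other, so the exchange of the group with 0 hydrogen-bond donors for the one with 1 leaves solubility unresolved between them as well. Nothing measured here speaks to why these read-outs sit so close together.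

Going by these compounds, whether a group of a different kind at this carbon, such as a carboxylic acid or a primary amine, would produce a step beyond the scatter in the Hepatocyte assay stays open. Also open, on these data alone, is whether the same closeness would hold on a core carrying something other than the chloro group or the acetamide.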